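This account rests on a few compounds, and the source may have more. Where it says the series, first, only, none or still open, it means among the compounds named here.

In an in vitro ADME assay on microsomes from liver (Homo sapiens) for metabolic stability (on this read-out higher numbers stand for fast clearance and lower numbers for slow clearance), compound 3 (`Cc1nnc(C2CCN(c3ccccn3)CC2)n1-c1ccc(C#N)cc1`) gives < 8 mL.min-1.g-1 as its read-out, and this is a limit of the assay, not a number. Compound 1 (`Cc1nnc(C2CCN(c3ccccn3)CC2)n1-c1ccccc1`), with hydrogen in place of the cyano, gives < 8 mL.min-1.g-1 as its read-out, again a limit. That makes the limit of < 8 mL.min-1.g-1 in this assay, at which 2 of the 3 values shown sit, the floor for this small set. Compound 2 (`Cc1ccc(-n2c(C)nnc2C2CCN(c3ccccn3)CC2)cc1`), with methyl in that place, gives 40 mL.min-1.g-1 as a true number.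

Compound 4 (`Cc1nnc(C2CCN(c3ccccn3)CC2)n1-c1ccc(Cl)cc1`) is still unmeasured. It has chloro in place of cyano on an aromatic carbon and so carries a 4-chlorophenyl instead of a 4-cyanophenyl.

All three measured steps change the group at this same place. Methyl in place of hydrogen gives an at least 5.0-fold higher number from compound 1 to compound 2 (0.69 log units; beyond the scatter) and cyano in place of methyl gives an at least 5.0-fold lower number from compound 2 to compound 3 (0.69 log units; beyond the scatter) as its result. Cyano in place of hydrogen gives a step that the two limits leave unreadable from compound 1 to compound 3 and so shows no size.

Among these three compounds only methyl lifts the read-out off the limit, and no chloro has been measured yet. Among the compounds with values here, a modest rise is therefore expected, smaller than the one seen with compound 2 at 40 mL.min-1.g-1 on this scale. The expected step is an at least 1.7-fold higher number from compound 3 to compound 4 (0.24 log units; that floor lies within the scatter) as an estimate, and the result could still come back as a limit. Compound 4 is expected at 14 mL.min-1.g-1 in this assay with an estimated range of 8 mL.min-1.g-1 to 35 mL.min-1.g-1 around it.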

Compound 4, intrinsic clearance in microsomes: 23 mL.min-1.g-1
Estimate against measurement, compound 4: 1.6-fold (0.22 log units) below, within the range that was stated.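

Within the data shown here, putting a 4-chlorophenyl in place of the 4-cyanophenyl gives an at least 2.8-fold higher number from compound 3 to compound 4 (0.45 log units; beyond the scatter), and chloro in place of hydrogen gives an at least 2.8-fold higher number from compound 1 to compound 4 (0.45 log units; beyond the scatter), so methyl is no longer the only group at this place that raises the read-out in this assay off the limit. Chloro in place of methyl gives a 1.7-fold lower number from compound 2 to compound 4 (0.24 log units; within the scatter), so this clearance read-out does not separate these two groups, and the four compounds now fall into two pairs, with chloro and methyl giving true numbers. Hydrogen and cyano form the other pair, as compound 1 and compound 3 each give only a limit of the assay, not a number: the limit of < 8 mL.min-1.g-1 in this assay, at which 2 of the 4 values shown sit.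

The compounds shown leave open how a fluoro, a methoxy or an amine at this same place would read, and whether any of them would join the chloro and methyl pair or the hydrogen and cyano pair. They also leave open how large the rises from the limit truly are and which part of the molecule is being cleared, while the step between compound 1 and compound 3 cannot be read at all.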